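This account rests on a few compounds, and the source may have more. Where it says the series, first, only, none or still open, it means among the compounds named here.

Measured so far in a functional assay on PC-3 cells (Homo sapiens) for antiproliferative activity, read by MTT assay, with a stated time of 72 h; on this read-out lower numbers stand for stronger inhibition and higher numbers for weaker inhibition:
- compound 1 `COc1cc(/C=C/C(=O)/C=C(O)/C=C/c2ccc(OC(=O)C(C)(CO)CO)c(OC)c2)ccc1OC(=O)C(C)(CO)CO` gives 3900 nM
- compound 2 `CCC(CO)(CO)C(=O)Oc1ccc(/C=C/C(=O)/C=C(O)/C=C/c2ccc(OC(=O)C(CC)(CO)CO)c(OC)c2)cc1OC` gives 4210 nM
- compound 3 `COc1cc(/C=C/C(O)=C/C(=O)/C=C/c2ccc(OC(=O)C(C)(CO)CO)c(OC)c2)ccc1O` gives 17400 nM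

Compound 3 carries the highest number of the three. Compound 4 `CCC(CO)(CO)C(=O)Oc1ccc(/C=C/C(=O)/C=C(O)/C=C/c2ccc(O)c(OC)c2)cc1OC` departs from compound 3 by one change (methyl in place of hydrogen on a saturated chain carbon, two bonds along the chain from a carbonyl carbon): methyl in place of hydrogen on a saturated chain carbon, two bonds along the chain from a carbonyl carbon. Among the measured compounds shown here, no measured step shows this change itself. For the measured compounds named here, the one step at hand (a 4.5-fold higher number from compound 1 to compound 3 (0.65 log units; beyond the scatter)) is modest and concerns a different change, hydrogen in place of (1,1-bis(hydroxymethyl)ethyl)carbonyl on an oxygen on an aromatic ring. The values of compound 1 (3900 nM) and compound 2 (4210 nM) lie within the scatter of each other. So no shift beyond the scatter is expected in this assay, and the estimated move is small (a 1.0-fold higher number from compound 3 to compound 4 (0.01 log units; within the scatter)). Compound 4 is expected at 18000 nM (estimated range 9000 nM to 34000 nM).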

Compound 4, half-maximal inhibitory concentration: 12500 nM
Beside the measured number, compound 4's estimate is 1.4-fold (0.16 log units) above it; the range from low to high includes it.
By their numbers in this assay, from the lowest: compounds 1 and 2 (each within the scatter of the next); then compounds 4 and 3 (each within the scatter of the next).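

In this assay, the change from 1,1-bis(hydroxymethyl)ethyl to 1,1-bis(hydroxymethyl)propyl is now read directly as a 1.4-fold lower number from compound 3 to compound 4 (0.14 log units; within the scatter) and so stays within the scatter at this saturated chain carbon. Taking the (1,1-bis(hydroxymethyl)propyl)carbonyl group off the oxygen on the aromatic ring gives a 3.0-fold higher number from compound 2 to compound 4 (0.47 log units; beyond the scatter) and shows that a modest step also follows the loss of this longer acyl group. No evidence at hand explains either step. Going by these compounds, whether a longer chain than ethyl at this carbon, or an amine in place of a hydroxymethyl group, would move the number remains open.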